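The compounds below may be only part of what the source reports. "The series", "measured", "known", "first", "only" and "open" are said of these compounds alone.

In an assay on CHO cells for displacement of a labelled ligand from prostaglandin E2 receptor EP1 subtype (Homo sapiens) (a lower number here means a stronger inhibitor, a higher number a weaker inhibitor), compound 1 `CCc1ccccc1N(Cc1nnc(Cc2ccc(Cl)cc2)o1)S(=O)(=O)c1ccc(C)cc1` gives 398 nM, the higher of the two single numbers in hand. Compound 3 `Cc1ccc(S(=O)(=O)N(Cc2nnc(Cc3ccc(C(F)(F)F)cc3)o2)c2cccc(Cl)c2C)cc1` gives 50.1 nM, a clearly lower number than compound 1. Compound 2 `CCc1ccccc1N(Cc1nnc(Cc2ccc(OC)cc2)o1)S(=O)(=O)c1ccc(C)cc1` gives 126 nM; 126 nM (2 entries) in two entries, also lower than compound 1. Compound 4 `CCc1ccccc1N(Cc1nnc(Oc2ccc(OC)cc2)o1)S(=O)(=O)c1ccc(C)cc1` differs from compound 1 by 4-methoxyphenoxy in place of 4-chlorobenzyl on an aromatic carbon. Among the compounds with values here, no measured pair isolates this exchange, so its size is open. A modest drop toward a lower number is expected, because compound 2 gives 126 nM; 126 nM (2 entries) with a related substitution pattern on that position. The expected step is a 2.2-fold lower number from compound 1 to compound 4 (0.34 log units; beyond the scatter), near the edge of the scatter. Compound 4 is estimated at 180 nM, with a range from 50 nM to 600 nM.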

Compound 4, half-maximal inhibitory concentration: < 1000 nM
Compound 4 ended at the assay's limit (the forecaster's own chance of this, stated with the estimate: 5%); the middle value does not contradict the limit.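

In this assay, within the data shown here, compound 4 gives < 1000 nM, a limit of the assay and not a number, so no step from compound 1 to compound 4 can be read. The compounds shown leave open how 4-methoxyphenoxy in place of 4-chlorobenzyl changes the number.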